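The source may report more compounds than this note shows. Statements on the series, on what has been measured and on what is new or still open speak of the compounds shown alone.

Compound 2, `CC(C)C(c1ccc(-c2ccc3cccc(F)c3c2)[nH]c1=O)C1C(=O)NC(=O)N1C`, is one of three compounds that share a core and have been run in a physicochemical assay for solubility, measured as kinetic solubility, at pH 2; on this read-out higher numbers stand for higher solubility and lower numbers for lower solubility. In this assay compound 2 gives 13600 nM, the highest of the three numbers. Compound 1, `CCC(CC)C(/C=C1\OC(=O)NC1=O)c1ccc(-c2ccc3cccc(F)c3c2)[nH]c1=O`, gives 3680 nM in this assay, and compound 3, `O=C1NC(=O)/C(=C/C(Cc2ccccc2)c2ccc(-c3ccc4cccc(F)c4c3)[nH]c2=O)O1`, gives 900 nM. Within the data shown here, the one step among the measured compounds that changes a single place is a 4.1-fold lower number from compound 1 to compound 3 (0.61 log units; beyond the scatter), a change in the group carried on the saturated chain carbon, not in the ring attached to it.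

Compound 4, `CC(C)C(/C=C1\SC(=O)NC1=O)c1ccc(-c2ccc3cccc(F)c3c2)[nH]c1=O`, has not yet been measured in this assay. It differs from compound 2 in one place: a group of 8 heavy atoms (4 carbon, 1 nitrogen, 2 oxygen, 1 sulfur; one five-membered non-aromatic ring with 2 hetero atoms) in place of a group of 8 heavy atoms (4 carbon, 2 nitrogen, 2 oxygen; one five-membered non-aromatic ring with 2 hetero atoms), on a saturated chain carbon bound to an aromatic carbon and a saturated chain carbon. Among the measured compounds shown here, no measured step covers such a ring change, so the measured step between compound 1 and compound 3 does not bear on it directly. What the data do show is that compound 1, which carries an exocyclic double bond into its five-membered ring as compound 4 does, gives a lower number than compound 2 in this assay. On that basis, the expected step is a 3.4-fold lower number from compound 2 to compound 4 (0.53 log units; beyond the scatter), a fall beyond the usual scatter. For compound 4 the estimated solubility in this assay is 4000 nM, with a range from 1200 nM to 13000 nM.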

Compound 4, solubility: 4800 nM
For compound 4 the middle estimate is 1.2-fold (0.08 log units) below the measured one, within the range that was stated.
By their numbers in this assay, from the lowest: compound 3; then compounds 1 and 4 (each within the scatter of the next); then compound 2.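

Among these compounds, the step of a 2.8-fold lower number from compound 2 to compound 4 (0.45 log units; beyond the scatter) in this assay is the first measured change of the ring group itself, and it lies beyond the scatter; the only earlier step changed a different group, on a saturated chain carbon bound to a double-bonded chain carbon. Here, 3-methyl-2,5-dioxoimidazolidin-4-yl leaves and the entering group has the same count of 8 heavy atoms and also holds one five-membered non-aromatic ring with 2 hetero atoms, so the read-out at this place responds to a change that leaves both of those counts as they were. No measurement shown gives a reason for the size or direction of this step.

Several things change together in this one swap: sulfur enters, the count of double bonds outside aromatic rings goes from 2 to 3, and the count of hydrogen-bond acceptors goes from 2 to 3, so the compounds shown cannot assign the step to any one of them. As far as these compounds go, it also remains open how a carboxylic acid or an amine on this saturated chain carbon, in place of either ring group, would read in this assay.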